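Moving the Bromine on the Hydrazone Phenyl Ring

This account rests on a few compounds, and the source may have more. Where it says the series, first, only, none or still open, it means among the compounds named here.

Compound 1 `Cc1c(C(=O)N/N=C\c2ccccc2F)oc2cccc(O)c12` — in a functional assay on PC-3 cells (Homo sapiens) for inhibition (a higher number here means a weaker inhibitor, a lower number a stronger inhibitor), compound 1 gives >= 40000 nM, which is a limit of the assay.
Compound 2 `Cc1c(C(=O)N/N=C\c2ccc(Br)cc2O)oc2cccc(O)c12` — in this assay compound 2 gives 2050 nM.

Among the compounds with values here, compound 2 therefore stands as the only true number here; the reading for compound 1 is a limit (the limit of >= 40000 nM in this assay, at which 1 of the 2 values shown sits). Within the data shown here, the single measured step, an at least 19-fold lower number from compound 1 to compound 2 (1.29 log units; beyond the scatter), was large, but it changed both substituents on the ring at once. Compound 3 `Cc1c(C(=O)N/N=C\c2cccc(Br)c2O)oc2cccc(O)c12` keeps the hydroxyl and only relocates the bromine: 3-bromo-2-hydroxyphenyl in place of 4-bromo-2-hydroxyphenyl on a carbon with a double bond to nitrogen. That measured step bears only loosely on such a move. For compound 3 the expected step is a 1.2-fold higher number from compound 2 to compound 3 (0.09 log units; within the scatter). Compound 3 is estimated at 2500 nM, between 800 nM and 8000 nM.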

Compound 3, half-maximal inhibitory concentration: 16600 nM
Beside the measured number, compound 3's estimate is 6.6-fold (0.82 log units) below it; measured number outside the range, above it.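

Where the bromine sits matters on its own, with the hydroxyl kept: in this assay the move gives an 8.1-fold higher number from compound 2 to compound 3 (0.91 log units; beyond the scatter) and so costs much of the gain seen earlier. Even so, 3-bromo-2-hydroxyphenyl in place of 2-fluorophenyl still gives an at least 2.4-fold lower number from compound 1 to compound 3 (0.38 log units; beyond the scatter) on the same shared core. That comparison rests on compound 1, whose reading is a limit of the assay: the limit of >= 40000 nM in this assay, at which 1 of the 3 values shown sits. The compounds shown leave open whether an amine or a carboxylic acid in place of the bromine would keep the number of compound 2.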